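Swapping the Side Group of Compound 2

A few compounds are considered here, and "the series" means these few. Any claim that something is new, unique, unknown or untested is made for them only; others in the source may bear on it.

In a functional assay on HepG2 cells (Homo sapiens) for antiproliferative activity, read by MTT assay, with a stated time of 48 h (on this read-out lower numbers stand for stronger inhibition and higher numbers for weaker inhibition), compound 1 (`COc1ccc(CN(C(=O)Cn2cc(COc3ccc4c(C)cc(=O)oc4c3)nn2)c2cc(OC)c(OC)c(OC)c2)cc1`) gives 1740 nM and compound 2 (`COc1ccc(CN(C(=O)Cn2cc(CSc3nc4ccccc4o3)nn2)c2cc(OC)c(OC)c(OC)c2)cc1`) gives 15600 nM as the higher of the two numbers, a gap beyond the scatter. Compound 3 (`COc1ccc(CN(C(=O)Cn2cc(CNS(=O)(=O)c3ccc(Br)cc3)nn2)c2cc(OC)c(OC)c(OC)c2)cc1`) carries ((4-bromophenyl)sulfonyl)amino in place of (1,3-benzoxazol-2-yl)sulfanyl on a saturated chain carbon bound to an aromatic carbon. For the measured compounds named here, no measured step covers this change. Compound 1 at 1740 nM shows that a lower number is possible on the shared core. In this assay the expected step of a 2.6-fold lower number from compound 2 to compound 3 (0.41 log units; beyond the scatter) is moderate and points toward stronger inhibition. Compound 3 is expected to give 6000 nM with 1500 nM to 25000 nM as its estimated range.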

Compound 3, half-maximal inhibitory concentration: 7370 nM
Compound 3: the middle estimate sits 1.2-fold (0.09 log units) below what was measured; low and high end bracket the measured number.
By their numbers in this assay, from the lowest: compound 1; then compound 3; then compound 2.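

Putting ((4-bromophenyl)sulfonyl)amino in place of (1,3-benzoxazol-2-yl)sulfanyl on a saturated chain carbon bound to an aromatic carbon gives a 2.1-fold lower number from compound 2 to compound 3 (0.33 log units; beyond the scatter) in this assay. The five-membered aromatic ring of the leaving group is therefore not needed at this place for a modest gain, and a group with one hydrogen-bond donor is accepted there. Nothing measured here accounts for the step. On these data alone, whether the bromine or the sulfonyl part carries the step stays open, as does how an amine or a carboxylic acid would fare at this place.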